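One Side-Chain Exchange and an Expected Oral Effect

The compounds below may be only part of what the source reports. "The series", "measured", "known", "first", "only" and "open" are said of these compounds alone.

Three measured compounds share one core and differ only in the group on the saturated chain carbon bound to an amide-type nitrogen and a carbonyl carbon. In a functional assay on the whole organism (Tail, strain ICR) with Mus musculus as the target, in the tail flick test, with a stated time of 120 min, at a dose of 25 umol/kg by the oral route (a higher number here means a stronger effect of the compound at the dose given, a lower number a weaker effect), compound 1 `N=C(N)NCCC[C@H](NC(=O)CN(c1nc(Cl)nc2[nH]cnc12)C1CC1)C(=O)O` gives 17%, compound 2 `CC[C@H](C)[C@H](NC(=O)CN(c1nc(Cl)nc2[nH]cnc12)C1CC1)C(=O)O` gives 21.4%, and compound 3 `C[C@@H](O)[C@H](NC(=O)CN(c1nc(Cl)nc2[nH]cnc12)C1CC1)C(=O)O` gives 37.6%. Compound 3 stands highest of the three: the step of a number 20.6 percentage points higher from compound 1 to compound 3 (beyond the scatter) and the step of a number 16.2 percentage points higher from compound 2 to compound 3 (beyond the scatter) both lie beyond the scatter, whereas the step of a number 4.4 percentage points higher from compound 1 to compound 2 (within the scatter) does not.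

Compound 4 `O=C(O)C[C@H](NC(=O)CN(c1nc(Cl)nc2[nH]cnc12)C1CC1)C(=O)O` has not yet been measured in this assay. It differs from compound 3 in one place: carboxymethyl in place of 1-hydroxyethyl on a saturated chain carbon bound to an amide-type nitrogen and a carbonyl carbon. For the measured compounds named here, no measured step exchanges 1-hydroxyethyl for carboxymethyl, so the bearing of the known steps is indirect. The nearest comparisons are the step of a number 16.2 percentage points higher from compound 2 to compound 3 (beyond the scatter), in which hydroxy replaced ethyl at this place, and the step of a number 20.6 percentage points higher from compound 1 to compound 3 (beyond the scatter). Both show that the group at this place can shift the number by a modest amount, and both leave compound 3 as the high mark, so moving away from its 1-hydroxyethyl is expected to cost rather than gain. Compound 4 is therefore expected to give 25%, within a range from 10% to 42%, the expected step being a number 12.6 percentage points lower from compound 3 to compound 4 (beyond the scatter).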

Compound 4, a percentage reported as activity, at one dose (the size of the read-out at that dose, not a potency): 22%
The estimate for compound 4 lay 3 percentage points above the measured number; the range from low to high includes it.
By their numbers in this assay, from the lowest: compounds 1, 2 and 4 (each within the scatter of the next); then compound 3.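

In this assay, carboxymethyl in place of 1-hydroxyethyl gives a number 15.6 percentage points lower from compound 3 to compound 4 (beyond the scatter), so a second group, alongside sec-butyl and the group of compound 1, now falls beyond the scatter from compound 3, and this one has the same computed counts of hydrogen-bond donors and acceptors as the 1-hydroxyethyl it replaces. Carboxymethyl cannot be told apart from the other two groups, with a number 0.6 percentage points higher from compound 2 to compound 4 (within the scatter) and a number 5 percentage points higher from compound 1 to compound 4 (within the scatter), so among the four compounds at this place only the 1-hydroxyethyl of compound 3 stands apart, while three groups of quite different make-up fall together. No measurement is available that would explain why this one group stands apart.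

The compounds shown leave open whether the hydroxy alone carries the higher number, which hydroxymethyl, lacking the methyl of 1-hydroxyethyl, or 1-methoxyethyl, with the hydroxy capped, could separate. They also leave open whether carboxymethyl stays level with sec-butyl when its carboxylic acid gives way to a primary amide or a methyl ester, or when the chain is lengthened to carboxyethyl.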